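Solubility When a Benzothiazole Replaces Hydroxypiperidine

A few compounds are considered here, and "the series" means these few. Any claim that something is new, unique, unknown or untested is made for them only; others in the source may bear on it.

Compound 1 `OC1CCN(c2nccnc2OC2CN(c3ccc4ccccc4n3)C2)CC1` gives 99000 nM in a physicochemical assay for solubility, in phosphate buffer, at pH 7.4; a higher number here means a more soluble compound, a lower number a less soluble compound. Compound 2 `c1ccc2nc(N3CC(Oc4nccnc4N4CCCCC4)C3)ccc2c1` gives only a limit of this assay, < 1000 nM. Compound 3 `c1ccc2nc(N3CC(Oc4nccnc4-c4cccc5ncccc45)C3)ccc2c1` gives 47000 nM in this assay.

Among the numbers shown, compound 1 stands highest; its nearest neighbour is compound 3, with a 2.1-fold lower number from compound 1 to compound 3 (0.32 log units; beyond the scatter). The value of compound 2 is a limit and not a number (the limit of < 1000 nM in this assay, at which 1 of the 3 values shown sits), so it marks only a floor.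

Compound 4 `c1ccc2nc(N3CC(Oc4nccnc4-c4ccc5scnc5c4)C3)ccc2c1` is the unmeasured member of the set. It differs from compound 1 in one place: 1,3-benzothiazol-5-yl in place of 4-hydroxypiperidin-1-yl on an aromatic carbon. Among the measured compounds shown here, two measured steps bear on this change. The step of a 2.1-fold lower number from compound 1 to compound 3 (0.32 log units; beyond the scatter) is the closest parallel, since there too a fused aromatic bicycle replaced the 4-hydroxypiperidin-1-yl group, and the outcome was a modest lowering. The step of an at least 47-fold higher number from compound 2 to compound 3 (1.67 log units; beyond the scatter) shows that such a bicycle sits far above the plain piperidin-1-yl analogue. For compound 4 the expectation is therefore a lowering relative to compound 1, of modest to somewhat larger size, as a 5.0-fold lower number from compound 1 to compound 4 (0.69 log units; beyond the scatter). Compound 4 is estimated at 20000 nM in this assay, with a range from 3000 nM to 60000 nM.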

Compound 4, solubility: < 1000 nM
Compound 4: a limit, no number; the forecaster's own chance of this, stated with the estimate: 15%; at least 20-fold (1.30 log units) between middle value and limit.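

At this place, on an aromatic carbon next to the ring nitrogen, the earlier compounds had shown a fused aromatic bicycle staying close to the 4-hydroxypiperidin-1-yl group, with a 2.1-fold lower number from compound 1 to compound 3 (0.32 log units; beyond the scatter), but in this assay that does not hold for every such bicycle, since 1,3-benzothiazol-5-yl gives an at least 99-fold lower number from compound 1 to compound 4 (1.99 log units; beyond the scatter). The exchange of one bicycle for the other is itself a large step, an at least 47-fold lower number from compound 3 to compound 4 (1.67 log units; beyond the scatter), so the outcome at this position depends on which bicycle is attached and not merely on a fused aromatic group being there. The value of compound 4 is a limit and not a number, so both of its readable steps give only a smallest size, and compound 4 now sits at the same limit as compound 2: the limit of < 1000 nM in this assay, at which 2 of the 4 values shown sit.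

As far as these compounds go, the step from compound 2 to compound 4 cannot be read, as both values are limits, so the order of these two compounds stays unknown. Also open, from the compounds shown here alone, is whether a plain phenyl ring, a pyridine ring or a morpholine ring at this place would fall with compound 3 or with compound 4, and what part the sulfur of the 1,3-benzothiazol-5-yl group plays.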